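A trifluoromethyl swap at the limit of the assay

A few compounds are considered here, and "the series" means these few. Any claim that something is new, unique, unknown or untested is made for them only; others in the source may bear on it.

Measured so far in an ADME assay on MT4 cells (Homo sapiens) for cytotoxicity, read by MTT assay, with a stated time of 3 days; on this read-out higher numbers stand for lower toxicity in this test and lower numbers for higher toxicity in this test:
Compound 1 `CC(C)(C)N(Cc1cccc([N+](=O)[O-])c1)C(=O)COC(=O)c1ccc([N+](=O)[O-])o1`: > 100000 nM
Compound 2 `CC(C)(C)N(Cc1ccc(F)cc1)C(=O)COC(=O)c1ccc([N+](=O)[O-])o1`: > 100000 nM

Compound 2 gives > 100000 nM, which is a limit of the assay and not a number. Compound 1 gives > 100000 nM, which is likewise a limit. Everything measured so far therefore sits at the limit of > 100000 nM in this assay, at which 2 of the 2 values shown sit.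

The next compound is compound 3 `CC(C)(C)N(Cc1ccc(C(F)(F)F)cc1)C(=O)COC(=O)c1ccc([N+](=O)[O-])o1`. Its difference from compound 2 is trifluoromethyl in place of fluoro on an aromatic carbon, with trifluoromethyl in place of fluoro on an aromatic carbon.

Within the data shown here, only one measured step bears on this change: a step that the two limits leave unreadable from compound 1 to compound 2. It exchanged 3-nitrophenyl for 4-fluorophenyl, but it has no readable size and offers no measured guide. In this assay, no step beyond the usual scatter is expected, and no direction can be argued. The expected result is a number no higher from compound 2 to compound 3 (the limit leaves the size open), and the assay may well report only a limit again. For compound 3 the estimated value is 100000 nM, with an expected range of 40000 nM to 200000 nM.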

Compound 3, half-maximal cytotoxic concentration: 71000 nM
Compound 3: the middle estimate sits 1.4-fold (0.15 log units) above what was measured; the range from low to high includes it.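

In this assay, among these compounds, compound 3 gives 71000 nM, the only value shown so far that is a number and not a limit. Trifluoromethyl in place of fluoro on the aromatic carbon gives an at least 1.4-fold lower number from compound 2 to compound 3 (0.14 log units; that floor lies within the scatter), and 4-(trifluoromethyl)phenyl in place of 3-nitrophenyl gives an at least 1.4-fold lower number from compound 1 to compound 3 (0.14 log units; that floor lies within the scatter); each is only a floor on the step, so neither shows a change beyond the scatter, though the true step could be larger. The earlier step between the two other compounds cannot be read, and the series still rests largely on a limit: the limit of > 100000 nM in this assay, at which 2 of the 3 values shown sit.

On these data alone, the true size of the trifluoromethyl step stays open, since one end of it is a limit, and a single number cannot show whether this position matters in general in this assay. Also open, as far as these compounds go, is how a nitrile, a methoxy group or an amine on the same aromatic carbon would read, and whether any change elsewhere on the shared core would bring the value down further.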